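A Swap at the Aniline End of a Urea Series

The compounds below may be only part of what the source reports. "The series", "measured", "known", "first", "only" and "open" are said of these compounds alone.

Three compounds share a core and were tested in a functional assay on NCI-H1581 cells (Homo sapiens) for inhibition, read by MTT assay, with a stated time of 48 h, tested at 10 uM; on this read-out lower numbers stand for less inhibition and higher numbers for more inhibition at the one concentration tested (going by the name of the read-out). Compound 1 `COc1cc(NC(=O)Nc2cc(Nc3ccc(C(C)(C)C)cc3)ncn2)cc(OC)c1` gives 38.7%, the lowest of the three numbers shown. Compound 2 `Cc1ccc(Nc2cc(NC(=O)Nc3c(Cl)cccc3Cl)ncn2)cc1F` gives 45.3%, which sits within the scatter of compound 1. Compound 3 `Cc1ccc(Nc2cc(NC(=O)Nc3c(Cl)cccc3Cl)ncn2)cc1C` gives 73.3%, beyond the scatter from compound 1. Within the data shown here, the only step between two measured compounds that differ in one place is a number 28 percentage points higher from compound 2 to compound 3 (beyond the scatter), a methyl in place of a fluoro on an aromatic carbon of the aryl group bound to the ring nitrogen.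

Compound 4 `COc1cc(NC(=O)Nc2cc(Nc3cc(I)ccc3OC)ncn2)cc(OC)c1` has not yet been measured. It differs from compound 1 in this way: 5-iodo-2-methoxyphenyl in place of 4-(tert-butyl)phenyl on a nitrogen on an aromatic ring. The change sits on the same nitrogen whose aryl group was altered between compound 2 and compound 3, but the group exchanged is different, so that step is only loosely informative; it shows that changes on this aryl group can move this assay modestly. A modest step in either direction is therefore plausible, and compound 4 is expected to give 45%, within 25% to 65%, an estimated step of a number 6.3 percentage points higher from compound 1 to compound 4 (within the scatter).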

Compound 4, a percentage reported as inhibition, at one concentration (the size of the read-out at that concentration, not a potency): 59%
Estimate against measurement, compound 4: 14 percentage points below, within the range that was stated.
By their numbers in this assay, from the lowest: compounds 1 and 2 (each within the scatter of the next); then compound 4; then compound 3.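

With 5-iodo-2-methoxyphenyl in place of 4-(tert-butyl)phenyl on the nitrogen, the read-out in this assay shows a number 20.3 percentage points higher from compound 1 to compound 4 (beyond the scatter). The earlier step, a number 28 percentage points higher from compound 2 to compound 3 (beyond the scatter), was a single substituent swap on this aryl group in compounds with a different group on the urea; this one shows that exchanging the whole aryl group also moves the number with the urea group of compound 1. Nothing available explains the rise.

The iodo and methoxy substituents enter together, so the compounds shown do not separate what each contributes to this step. Also open, from the compounds shown here alone, is how an amine or a carboxylic acid on this aryl group would read, and whether this exchange would give a similar step with the urea group of compound 3.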